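A few compounds are considered here, and "the series" means these few. Any claim that something is new, unique, unknown or untested is made for them only; others in the source may bear on it.

Series notes

- compound 1 `COc1cc2c(Oc3ccc(NC(=O)c4nn(-c5ccccc5)c(=O)c5ccccc45)cc3F)ccnc2cc1OCCCN1CCCC1` — 1130 nM in a functional assay on MDA-MB-231 cells (Homo sapiens) for cytotoxicity, read by MTT assay, with a stated time of 72 h; a higher number here means a weaker inhibitor, a lower number a stronger inhibitor
- compound 2 `COc1cc2c(Oc3ccc(NC(=O)c4nn(-c5ccccc5)c(=O)c5ccccc45)cc3F)ccnc2cc1OCCCN1CCN(C)CC1` — 1580 nM in this assay

Among the measured compounds shown here, compound 2 holds the higher of the two numbers measured so far, but the only measured step, a 1.4-fold higher number from compound 1 to compound 2 (0.15 log units; within the scatter), lies within the scatter, so compound 1 and compound 2 cannot be ordered against each other. Compound 3 `COc1cc2c(Oc3ccc(NC(=O)c4nn(-c5ccc(F)cc5)c(=O)c5ccccc45)cc3F)ccnc2cc1OCCCN1CCN(C)CC1` is not yet measured. It differs from compound 2 by fluoro in place of hydrogen on an aromatic carbon. For the measured compounds named here, the one measured step concerns the amine at the end of the chain and leaves the phenyl untouched, so no measured step bears directly on this hydrogen-to-fluoro exchange. With a substituent that has not been varied in this series, the working expectation for compound 3 is a step of a 1.1-fold lower number from compound 2 to compound 3 (0.02 log units; within the scatter), that is, none beyond the scatter. Compound 3 is accordingly estimated at 1500 nM, with a range from 600 nM to 4000 nM.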

Compound 3, half-maximal inhibitory concentration: 460 nM
Compound 3: middle estimate off by 3.3-fold (0.51 log units), on the high side, outside the stated range (below it).
By their numbers in this assay, from the lowest: compound 3; then compounds 1 and 2 (each within the scatter of the next).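

Among the compounds shown here, the phenyl on the shared core is the first place where a single change moves the number in this assay beyond the scatter: fluoro in place of hydrogen, para to a large group, gives a 3.4-fold lower number from compound 2 to compound 3 (0.54 log units; beyond the scatter) in this series. For the compounds shown here, the amine exchange at the end of the chain, a 1.4-fold higher number from compound 1 to compound 2 (0.15 log units; within the scatter), stays within the scatter, so this hydrogen-to-fluoro exchange is the only measured change that separates two compounds. No measurement shown accounts for the size of the fluoro step.

Going by these compounds, it remains open whether chloro, methyl or methoxy at the same carbon would give a similar step, or whether the effect is specific to fluoro. On these data alone, it also remains open whether fluoro gives the same step with pyrrolidin-1-yl at the end of the chain.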